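The source may report more compounds than this note shows. Statements on the series, on what has been measured and on what is new or still open speak of the compounds shown alone.

Measured so far:
- compound 1, `Cc1ccccc1C(=O)OC1(C(=O)Nc2ccc([N+](=O)[O-])cc2)CCCCC1`: 516 nM
- compound 2, `O=C(OC1(C(=O)Nc2ccc([N+](=O)[O-])cc2)CCCCC1)c1ccc(Br)cc1`: 237 nM
- compound 3, `O=COC1(C(=O)Nc2ccc([N+](=O)[O-])cc2)CCCCC1`: 35.4 nM

All three were tested in a functional assay on MCF7 cells (Homo sapiens) for inhibition, read by MTT assay, with a stated time of 72 h; on this read-out higher numbers stand for weaker inhibition and lower numbers for stronger inhibition. Compound 1 gives the highest number of the three; compound 2 comes nearest to it and compound 3 lies furthest away. The step of a 2.2-fold lower number from compound 1 to compound 2 (0.34 log units; beyond the scatter) was modest, while a 15-fold lower number from compound 1 to compound 3 (1.16 log units; beyond the scatter) was large; the step of a 6.7-fold lower number from compound 2 to compound 3 (0.83 log units; beyond the scatter) was modest as well.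

Compound 4, `CC(=O)OC1(C(=O)Nc2ccc([N+](=O)[O-])cc2)CCCCC1`, has not yet been measured. It differs from compound 1 in one place: methyl in place of 2-methylphenyl on a carbonyl carbon. The measured steps that bear on this change are the two that alter the same carbonyl carbon of compound 1. Replacing the 2-methylphenyl with hydrogen gave a 15-fold lower number from compound 1 to compound 3 (1.16 log units; beyond the scatter), and replacing it with a 4-bromophenyl gave a 2.2-fold lower number from compound 1 to compound 2 (0.34 log units; beyond the scatter). Methyl brings no ring, as the counted difference shows, yet it is not the bare hydrogen of compound 3, so a step between those two is expected. Compound 4 is therefore expected to give a lower number than compound 1 in this assay, with an expected step of a 6.1-fold lower number from compound 1 to compound 4 (0.78 log units; beyond the scatter). The estimate for compound 4 is 85 nM, with a range from 30 nM to 250 nM.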

Compound 4, half-maximal inhibitory concentration: 403 nM
The estimate for compound 4 lay 4.7-fold (0.68 log units) below the measured number; measured number above the stated range.
By their numbers in this assay, from the lowest: compound 3; then compounds 2, 4 and 1 (each within the scatter of the next, the first and the last beyond it).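

At this carbonyl carbon, a 1.3-fold lower number from compound 1 to compound 4 (0.11 log units; within the scatter) stays within the usual scatter in this assay even though a whole 2-methylphenyl ring gives way to a single methyl, and a 1.7-fold higher number from compound 2 to compound 4 (0.23 log units; within the scatter) also stays within it. Among these groups, then, having a ring here does not by itself separate the numbers, although compound 1 and compound 2, the two ring-bearing compounds, do differ slightly beyond the scatter. The large change lies elsewhere: an 11-fold higher number from compound 3 to compound 4 (1.06 log units; beyond the scatter) shows that adding just the methyl in place of hydrogen accounts for a gap as large as those seen with the rings, leaving the hydrogen of compound 3 alone at the strong end.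

Nothing measured here explains why hydrogen and methyl differ so sharply. From the compounds shown here alone, whether an ethyl group or a longer chain would stay close to methyl, and whether an amine on this carbonyl carbon would come closer to hydrogen, remains open.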